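Swapping the pyrimidine ring for a plain phenyl

The source may hold more compounds than are shown below. What is called first, only, known or untested is meant among the compounds shown, and "the series" means these compounds.

Compound 1 `O=C(Nc1ccccn1)c1ccccc1-c1ccccc1` and compound 2 `O=C(Nc1ccncn1)c1ccccc1-c1ccccc1` share one core and differ only in the ring on the amide nitrogen. In an in vitro functional assay on HEK ts201 cells for antagonist activity at Neuronal acetylcholine receptor; alpha4/beta2 (Homo sapiens), read by fluorescence and calcium flux (a lower number here means a stronger inhibitor, a higher number a weaker inhibitor), compound 1 gives 13600 nM, while compound 2 gives 25100 nM; the step of a 1.8-fold higher number from compound 1 to compound 2 (0.27 log units; within the scatter) lies within the scatter, so compound 2 stands with the higher of the two numbers but not meaningfully apart. Compound 3 `O=C(Nc1ccccc1)c1ccccc1-c1ccccc1` carries phenyl in place of pyrimidin-4-yl on an amide-type nitrogen. Going by the values given here, only the step from compound 1 to compound 2 bears on this, and it was small, so little change beyond the scatter is expected: a 1.4-fold lower number from compound 2 to compound 3 (0.14 log units; within the scatter). Compound 3 is therefore estimated at 18000 nM, ranging from 5000 nM to 60000 nM.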

Compound 3, half-maximal inhibitory concentration: 6900 nM
Beside the measured number, compound 3's estimate is 2.6-fold (0.42 log units) above it, and the stated range covers the measured number.
By their numbers in this assay, from the lowest: compounds 3, 1 and 2 (each within the scatter of the next, the first and the last beyond it).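

In this assay, going by these compounds alone, the all-carbon phenyl ring separates from the pyrimidin-4-yl group, with a 3.6-fold lower number from compound 2 to compound 3 (0.56 log units; beyond the scatter) as the first step to clear the scatter, though only modestly. Against the pyridin-2-yl group the phenyl ring does not separate, with a 2.0-fold lower number from compound 1 to compound 3 (0.29 log units; within the scatter) so compound 1 and compound 3 stand together. Still open, on these data alone, is how an amine or a carboxylic acid on the phenyl ring, or a longer chain on the amide-type nitrogen in its place, would read in this assay. Nothing available accounts for these differences.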